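A few compounds are considered here, and "the series" means these few. Any claim that something is new, unique, unknown or untested is made for them only; others in the source may bear on it.

Measured compounds:
- compound 1 `CC(C)(C)OC(=O)NCC(=O)Oc1cccc2oc(=O)[nH]c12` — 54.5%
- compound 2 `CC(C)C(NC(=O)OC(C)(C)C)C(=O)Oc1cccc2oc(=O)[nH]c12` — 46.5%

In a functional assay on the whole organism (Ear, strain Kunming) for inhibition, with Mus musculus as the target, with stated times of 45 min and 15 min, at a dose of 150 mg/kg by the oral route (a lower number here means less inhibition, a higher number more inhibition at the dose given (going by the name of the read-out)), compound 1 gives 54.5% and compound 2 gives 46.5%. Compound 2 holds the lowest of the two numbers, but its gap to compound 1 lies within the scatter, so no order between the two is claimed.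

Compound 3 `CSCCC(NC(=O)OC(C)(C)C)C(=O)Oc1cccc2oc(=O)[nH]c12` differs from compound 2 by 2-(methylsulfanyl)ethyl in place of isopropyl on a saturated chain carbon bound to an amide-type nitrogen and a carbonyl carbon. Within the data shown here, the only measured step at the same place is a number 8 percentage points lower from compound 1 to compound 2 (within the scatter), within the scatter. On that basis a step of a number 1.5 percentage points higher from compound 2 to compound 3 (within the scatter) is expected, none beyond the scatter. For compound 3 an inhibition of 48% is estimated, with a range from 35% to 61%.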

Compound 3, a percentage reported as inhibition, in the whole organism at one dose (the size of the read-out at that dose, not a potency): 24.8%
Estimate against measurement, compound 3: 23.2 percentage points above, outside the stated range (below it).
By their numbers in this assay, from the lowest: compound 3; then compounds 2 and 1 (each within the scatter of the next).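

Replacing isopropyl with 2-(methylsulfanyl)ethyl on this saturated chain carbon gives a number 21.7 percentage points lower from compound 2 to compound 3 (beyond the scatter) in this assay, and the same group in place of hydrogen gives a number 29.7 percentage points lower from compound 1 to compound 3 (beyond the scatter). The read-out at this position therefore responds to the side chain, which the isopropyl and hydrogen pair alone did not show. No evidence on the cause of this loss of inhibition is available.

Whether the sulfur atom or the chain itself accounts for the lower number remains open. A plain n-butyl chain at this carbon would separate the two, and an amine or a carboxylic acid there is not covered by the compounds shown.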